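Swapping a side group on a shared core

The source may hold more compounds than are shown below. What is called first, only, known or untested is meant among the compounds shown, and "the series" means these compounds.

Compound 1 `C=C(CC)C(=O)c1ccc(OCC(=O)NC(CS)C(=O)OCC)c(Cl)c1Cl` gives 4800 nM
Compound 2 `C=C(CC)C(=O)c1ccc(OCC(=O)Nc2ccc(/C=C/C(=O)O)cc2)c(Cl)c1Cl` gives 3000 nM

In a functional assay on CLL cells (Homo sapiens) for cytotoxicity, read by MTT assay, with a stated time of 48 h (a higher number here means that more compound is needed for the effect, a lower number that less compound is needed), compound 2 at 3000 nM and compound 1 at 4800 nM lie within the usual scatter of each other, so neither can be ranked ahead of the other. Compound 3 `C=C(CC)C(=O)c1ccc(OCC(=O)Nc2ccc(O)cc2)c(Cl)c1Cl` has not yet been measured. It departs from compound 2 in one place: hydroxy in place of 2-carboxyethenyl on an aromatic carbon. Going by the values given here, no measured pair shows what a change at this place does, so the data give no direction. Among the compounds with values here, the only guide is that compound 1 at 4800 nM and compound 2 at 3000 nM carry different side chains yet stay within the scatter of each other. No shift beyond the scatter is therefore expected in this assay, and the estimated change is small (a 1.2-fold higher number from compound 2 to compound 3 (0.07 log units; within the scatter)). Compound 3 is expected at 3500 nM (estimated range 1400 nM to 9000 nM).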

Compound 3, half-maximal effective concentration: 6400 nM
For compound 3 the middle estimate is 1.8-fold (0.26 log units) below the measured one, and the stated range covers the measured number.
By their numbers in this assay, from the lowest: compounds 2, 1 and 3 (each within the scatter of the next, the first and the last beyond it).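

In this assay, putting hydroxy in place of 2-carboxyethenyl on the aromatic carbon gives a 2.1-fold higher number from compound 2 to compound 3 (0.33 log units; beyond the scatter), a modest step but the first here to lie beyond the scatter, so the number does respond to the group at this place. By contrast, 4-hydroxyphenyl in place of 1-(ethoxycarbonyl)-2-sulfanylethyl on the amide-type nitrogen gives only a 1.3-fold higher number from compound 1 to compound 3 (0.12 log units; within the scatter), so that swap cannot be told apart from no change. Nothing available explains the step at the aromatic carbon.

Going by these compounds alone, with only two groups compared at this place, it remains open how an amine, a methoxy group or a longer chain there would behave. It is also unknown whether the same step would appear with a different group on the amide-type nitrogen.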